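Methoxy Additions on Two Boron-Bearing Cores

The source may report more compounds than this note shows. Statements on the series, on what has been measured and on what is new or still open speak of the compounds shown alone.

In a functional assay on HCT-116 cells (Homo sapiens) for antiproliferative activity, read by MTT assay, with a stated time of 72 h (a lower number here means a stronger inhibitor, a higher number a weaker inhibitor), compound 1 `O=C(CCc1cccc2c1B(O)OC2)Nc1cccc(-c2ccccc2)c1` gives 890 nM. Compound 2 `COc1ccc(-c2cccc(NC(=O)CCc3cccc4c3B(O)OC4)c2)cc1` carries methoxy in place of hydrogen on an aromatic carbon and in this assay compound 2 gives 160 nM, so that a 5.6-fold lower number from compound 1 to compound 2 (0.75 log units; beyond the scatter). Compound 3 `COc1cccc(-c2cccc(NC(=O)CCc3ccc4c(c3)COB4O)c2)c1` rests on a different core, and the difference between the two cores is not broken down here; in this assay compound 3 gives 81000 nM, the highest of the three numbers and beyond the scatter from both compound 1 and compound 2.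

Compound 4 `COc1cc(OC)cc(-c2cccc(NC(=O)CCc3ccc4c(c3)COB4O)c2)c1` is not yet measured. Among the measured compounds shown here, it differs from compound 3 by methoxy in place of hydrogen on an aromatic carbon, which is the same kind of change as the one from compound 1 to compound 2, though not at the same place: in compound 2 the methoxy stands para to a large group, whereas in compound 4 it stands meta to a large group and meta to a methoxy group. For the measured compounds named here, since the only measured instance of this change, from compound 1 to compound 2, lowered the number, a lowering is expected for compound 4 as well, and the author estimates a 2.0-fold lower number from compound 3 to compound 4 (0.31 log units; beyond the scatter) in this assay, held smaller than the earlier step because the place differs and the core of compound 3 starts from 81000 nM. Compound 4 is therefore expected to give about 40000 nM in this assay, within 12000 nM to 150000 nM.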

Compound 4, half-maximal inhibitory concentration: 56000 nM
Compound 4: the middle estimate sits 1.4-fold (0.15 log units) below what was measured, and the stated range covers the measured number.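

In this assay, methoxy in place of hydrogen on an aromatic carbon gives a 1.4-fold lower number from compound 3 to compound 4 (0.16 log units; within the scatter) and so leaves compound 4 indistinguishable from compound 3, whereas the same kind of change on the core of compound 1 gave a step beyond the scatter. The size of the step therefore did not carry over from one core to the other in this pair of examples: the same change on two cores in this assay, a 5.6-fold lower number (0.75 log units; beyond the scatter) from compound 1 to compound 2 and a 1.4-fold lower number (0.16 log units; within the scatter) from compound 3 to compound 4, 3.8-fold (0.58 log units) apart, beyond the scatter of two such steps.
This does not show that the core alone sets the size of the step, since the two changes also differ in place: the methoxy of compound 4 stands meta to a large group and meta to a methoxy group, on a ring that already carried one, and the two steps cannot separate the effect of the core from that of the place.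

The compounds shown leave open how the 3-methoxyphenyl and 3,5-dimethoxyphenyl groups would read on the core of compound 1, which would put core and place to a direct test. They also leave open whether a different group at this place on the core of compound 3, such as an amine or a carboxylic acid, would give a step beyond the scatter.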